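Vero cytotoxicity of a shared-core pair and one prospect

This account rests on a few compounds, and the source may have more. Where it says the series, first, only, none or still open, it means among the compounds named here.

Measured so far:
compound 1 `COc1cc(/C=C/c2nnc(-c3cc([N+](=O)[O-])cn3C)o2)ccc1O` — 203000 nM
compound 2 `Cn1cc([N+](=O)[O-])cc1-c1nnc(C2CCCNC2)o1` — 611000 nM

Both numbers come from an ADME assay on Vero cells (Chlorocebus sabaeus) for cytotoxicity, read by MTT assay, with a stated time of 72 h; on this read-out higher numbers stand for weaker inhibition and lower numbers for stronger inhibition. Compound 1 gives 203000 nM and compound 2 gives 611000 nM, so compound 2 carries the higher of the two numbers, and the gap between them is beyond the usual scatter of repeats. Within the data shown here, no single-change step between measured compounds is available, so the series offers no calibrated step size yet.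

The next compound, compound 3 `Cn1cc([N+](=O)[O-])cc1-c1nnc(-c2ccc[nH]2)o1`, differs from compound 2 in one place: 1H-pyrrol-2-yl in place of piperidin-3-yl on an aromatic carbon

Among the measured compounds shown here, with no related step on record, the expectation for the change from compound 2 to compound 3 rests only on the two values shown, and a step of a 1.7-fold lower number from compound 2 to compound 3 (0.24 log units; within the scatter) is estimated, running toward the number of compound 1 rather than away from it, though a result within the scatter would not surprise. Compound 3 is therefore expected at about 350000 nM, in the range 120000 nM to 1000000 nM in this assay.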

Compound 3, half-maximal inhibitory concentration: 208000 nM
The estimate for compound 3 lay 1.7-fold (0.23 log units) above the measured number, within the range that was stated.
By their numbers in this assay, from the lowest: compounds 1 and 3 (each within the scatter of the next); then compound 2.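

In this assay, among these compounds, the swap of piperidin-3-yl for 1H-pyrrol-2-yl gives a 2.9-fold lower number from compound 2 to compound 3 (0.47 log units; beyond the scatter) on the only single-change step so far, which shows that the group on this aromatic carbon, next to the ring oxygen, can move the number beyond the scatter. The leaving and entering groups differ at once in ring size, in aromatic character and in hydrogen-bond acceptors, and this one step cannot separate these differences. No measurement shown bears on why the number moves.

Open, as far as these compounds go, is whether a phenyl ring or an open-chain amine on this carbon would stand nearer compound 2 or compound 3 in this assay. Also open, from the compounds shown here alone, is whether piperidin-4-yl would keep the number of compound 2 or shift it.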